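The source may hold more compounds than are shown below. What is called first, only, known or untested is meant among the compounds shown, and "the series" means these compounds.

Measured so far in a functional assay on HASMC cells (Homo sapiens) for inhibition; a higher number here means a weaker inhibitor, a lower number a stronger inhibitor:
- compound 1 `CC(=O)Nc1cc(CO[C@@H]2O[C@@H](COC(=O)c3ccccc3)[C@H](O[C@H]3OC4CO[C@@H](c5ccccc5)OC4[C@H](O)[C@@H]3O)[C@H](O)[C@@H]2O)ccc1Cl` gives 20 nM in this assay.
- compound 2 `CC(=O)Nc1cc(CO[C@@H]2O[C@@H](COC(=O)c3ccccc3)[C@H](O[C@H]3OC4CO[C@@H](c5ccc(Cl)cc5)OC4[C@H](O)[C@@H]3O)[C@H](O)[C@@H]2O)ccc1Cl` gives 23 nM in this assay.

Among the compounds with values here, compound 2 stands at the higher of the two numbers, with compound 1 as its only neighbour; the gap between them is a 1.2-fold higher number from compound 1 to compound 2 (0.06 log units; within the scatter), so the two are indistinguishable within the scatter.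

Compound 3 `CC(=O)Nc1cc(CO[C@@H]2O[C@@H](COC(=O)c3ccccc3)[C@H](O[C@H]3OC4CO[C@@H](c5ccc([N+](=O)[O-])cc5)OC4[C@H](O)[C@@H]3O)[C@H](O)[C@@H]2O)ccc1Cl` is not yet measured. Its difference from compound 2 is nitro in place of chloro on an aromatic carbon, on an aromatic carbon of a six-membered aromatic ring of carbon only.

Within the data shown here, only one measured step bears on this position: a 1.2-fold higher number from compound 1 to compound 2 (0.06 log units; within the scatter), which put chloro there in place of hydrogen and left the number unchanged within the scatter. Among the measured compounds shown here, nothing measured speaks to nitro at that position; the one step seen says the position tolerated one change without effect. Compound 3 is therefore expected to stay near compound 2, with no step beyond the scatter in either direction, the expected step being a 1.1-fold higher number from compound 2 to compound 3 (0.04 log units; within the scatter). The estimate for compound 3 in this assay is 25 nM, with a range of 10 nM to 60 nM.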

Compound 3, half-maximal inhibitory concentration: 3 nM
For compound 3 the middle estimate is 8.3-fold (0.92 log units) above the measured one; the measured number lies below the stated range.
By their numbers in this assay, from the lowest: compound 3; then compounds 1 and 2 (each within the scatter of the next).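

In this assay the position no longer looks silent: the change from 4-chlorophenyl to 4-nitrophenyl gives a 7.7-fold lower number from compound 2 to compound 3 (0.88 log units; beyond the scatter) and, set against the unsubstituted phenyl, nitro gives a 6.7-fold lower number from compound 1 to compound 3 (0.82 log units; beyond the scatter) while chloro gave only a 1.2-fold higher number from compound 1 to compound 2 (0.06 log units; within the scatter) and so stayed within the scatter. The tolerance seen earlier therefore belongs to chloro alone and not to this place on the ring, para to a large group, where the group chosen can move the number beyond the scatter. Nitro enters with 2 hydrogen-bond acceptors and 3 heavy atoms where chloro has 0 acceptors and 1 heavy atom, but these three compounds cannot show which difference, if either, matters, and no other data bear on the reason for the step.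

From the compounds shown here alone, it remains open whether the gain is particular to nitro or is shared by other groups at this place, such as a nitrile, a carboxylic acid, an amine or a methyl ester. Within the data shown here, with only one compound standing apart from the other two, no trend across substituents can yet be drawn for the series.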